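The compounds below may be only part of what the source reports. "The series", "measured", "known", "first", "only" and "open" are said of these compounds alone.

Measured compounds in a functional assay on A875 cells (Homo sapiens) for antiproliferative activity, read by MTT assay, with a stated time of 48 h; on this read-out lower numbers stand for stronger inhibition and higher numbers for weaker inhibition:
Compound 1, `O=C(CSc1nnc(NC(=O)C(Cl)Cl)s1)Nc1ccc(Br)cn1`, gives 6500 nM.
Compound 2, `O=C(CSc1nnc(NC(=O)CCCl)s1)Nc1ccc(Br)cn1`, gives 430 nM.
Compound 3, `O=C(CCCl)Nc1ccc(SCC(=O)Nc2ccc(Br)cn2)cc1`, gives 24300 nM.

Compound 1 and compound 2 share a core and differ in one place: dichloromethyl in place of 2-chloroethyl on a carbonyl carbon. That change gives a 15-fold higher number from compound 2 to compound 1 (1.18 log units; beyond the scatter), so the dichloromethyl compound inhibits growth far less well than its 2-chloroethyl partner.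

Compound 3 carries the 2-chloroethyl group on a different core; how that core differs from the core of compound 2 is not broken down here. Compound 4, `O=C(CSc1ccc(NC(=O)C(Cl)Cl)cc1)Nc1ccc(Br)cn1`, is not yet measured; it stands to compound 3 as compound 1 stands to compound 2, the same change at the same kind of position: dichloromethyl in place of 2-chloroethyl on a carbonyl carbon.

Since the place of the change reads the same for both pairs, compound 4 is expected to lie on the weaker side of compound 3, with an estimated step of a 4.1-fold higher number from compound 3 to compound 4 (0.61 log units; beyond the scatter), resting on a 15-fold higher number from compound 2 to compound 1 (1.18 log units; beyond the scatter) in this assay while allowing that the core differs. The estimate for compound 4 in this assay is 100000 nM, between 25000 nM and 400000 nM.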

Compound 4, half-maximal inhibitory concentration: 56800 nM
The estimate for compound 4 lay 1.8-fold (0.25 log units) above the measured number; measured number inside the range.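

In this assay, putting dichloromethyl in place of 2-chloroethyl on the carbonyl carbon weakens growth inhibition on the second core as well, with a 2.3-fold higher number from compound 3 to compound 4 (0.37 log units; beyond the scatter) in a modest step. The direction of the change therefore carries over from one core to the other, but its size does not: the same change on two cores in this assay, a 15-fold higher number (1.18 log units; beyond the scatter) from compound 2 to compound 1 and a 2.3-fold higher number (0.37 log units; beyond the scatter) from compound 3 to compound 4, 6.5-fold (0.81 log units) apart, beyond the scatter of two such steps. Going by these compounds alone, this shows that the size of the step on one core cannot simply be copied to the other, but with only two pairs it does not show which part of the cores sets the size, or how the change would behave on a third core.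

The compounds shown hold only these two groups at this place, so it stays open how an unsubstituted methyl, a longer chain such as 3-chloropropyl, or a chain ending in an amine would behave on either core. From the compounds shown here alone, whether any such group would follow the same direction on both cores also remains unknown.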